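Adding a Methoxy Group to Two Weakly Cytotoxic Compounds

The source may report more compounds than this note shows. Statements on the series, on what has been measured and on what is new or still open speak of the compounds shown alone.

Compound 1 `Oc1ccccc1CNc1ncnc2c1ncn2C1CCCCO1` and compound 2 `COc1cccc(CNc2ncnc3c2ncn3C2CCCCO2)c1O` share one core, while compound 3 `COc1ccc(OC)c(CNc2ncnc3c2ncn3C2CCCO2)c1` and compound 4 `COc1cc(OC)c(OC)cc1CNc1ncnc2c1ncn2C1CCCO1` share another; the difference between the two cores is not broken down here.

In an ADME assay on MCF7 cells (Homo sapiens) for cytotoxicity, with a stated time of 72 h (a higher number here means a weaker inhibitor, a lower number a stronger inhibitor), compound 1 gives > 100000 nM, which is a limit of the assay and not a number. In this assay compound 2 gives > 100000 nM, again a limit rather than a number. Compound 2 differs from compound 1 by methoxy in place of hydrogen on an aromatic carbon. The step that the two limits leave unreadable from compound 1 to compound 2 is therefore unreadable, because both values sit at the limit of > 100000 nM in this assay, at which 2 of the 3 values shown sit.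

In this assay compound 3 gives > 50000 nM, which is also a limit and not a number. Its value is the limit of > 50000 nM in this assay, at which 1 of the 3 values shown sits.

Compound 4 differs from compound 3 by methoxy in place of hydrogen on an aromatic carbon. Among the measured compounds shown here, this is the same kind of change as the one from compound 1 to compound 2, but the surroundings differ: in compound 2 the entering methoxy sits ortho to a hydroxy group and meta to a large group, whereas in compound 4 it sits ortho to a methoxy group, meta to a methoxy group and para to a large group.

The expectation for compound 4 rests on compound 3 and its limit. In this assay the expected step is a step that the limit leaves unreadable from compound 3 to compound 4, estimated as small. Compound 4 is expected to give about 100000 nM, most likely between 30000 nM and 300000 nM, and quite possibly again only a limit.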

Compound 4, half-maximal inhibitory concentration: > 100000 nM
Compound 4: only a limit was reported; the forecaster's own chance of this, stated with the estimate: 80%; the middle value sits exactly at the limit.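

In this assay compound 4 gives > 100000 nM, which is a limit of the assay and not a number. Compound 3 also has only a limit, and no size can be read for the step between compound 3 and compound 4. The compounds shown leave open how strongly any of the four inhibits in this assay, and whether adding a methoxy group changes this on either core.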